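The compounds below may be only part of what the source reports. "The series", "measured", "known", "first", "only" and "open" are said of these compounds alone.

Compound 1 `O=C(O)c1[nH]cc(C(=O)NCc2ccc(F)cc2)c(=O)c1O` and compound 2 `NC(=O)c1[nH]cc(C(=O)NCc2ccc(F)cc2)c(=O)c1O` share one core and differ at a single carbonyl carbon. In an ADME assay on MT4 cells (Homo sapiens) for cytotoxicity, read by MTT assay, with a stated time of 4 days (a higher number here means that more compound is tolerated, a lower number that less compound is tolerated), compound 1 gives > 200000 nM, which is a limit of the assay rather than a number (the limit of > 200000 nM in this assay, at which 1 of the 2 values shown sits). In this assay, among the compounds with values here, compound 2 gives 40000 nM, the only actual number among the two values shown. The step of an at least 5.0-fold lower number from compound 1 to compound 2 (0.69 log units; beyond the scatter) came with amino in place of hydroxy on a carbonyl carbon. Compound 3 `CN(C)C(=O)c1[nH]cc(C(=O)NCc2ccc(F)cc2)c(=O)c1O` differs from compound 2 by dimethylamino in place of amino on a carbonyl carbon. Within the data shown here, the one measured step touches the same carbonyl carbon but exchanged a different group, so it bears on the new step only loosely. Compound 3 is therefore expected to shift little in this assay, by about a 1.3-fold lower number from compound 2 to compound 3 (0.12 log units; within the scatter). The estimate for compound 3 in this assay is 30000 nM, within 10000 nM to 100000 nM.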

Compound 3, half-maximal cytotoxic concentration: 5100 nM
Compound 3: the middle estimate sits 5.9-fold (0.77 log units) above what was measured; the whole stated range lies above it.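

In this assay, the result shows that this carbonyl carbon responds not only to replacing hydroxy but also to what is carried on the nitrogen, as dimethylamino in place of amino gives a 7.8-fold lower number from compound 2 to compound 3 (0.89 log units; beyond the scatter). Across the three compounds, less compound is tolerated at each step along the series hydroxy, amino, dimethylamino, and dimethylamino in place of hydroxy gives an at least 39-fold lower number from compound 1 to compound 3 (1.59 log units; beyond the scatter). Compound 1 stands at a limit of the assay and not at a number, so this last step is only a bound: the limit of > 200000 nM in this assay, at which 1 of the 3 values shown sits.

The compounds shown leave open how methylamino, which carries a single methyl group, would sit in this series. They also leave open whether a longer chain such as diethylamino, or a cyclic amine such as pyrrolidine, would lower the number further on this carbonyl carbon.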